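The compounds below may be only part of what the source reports. "The series", "measured", "known", "first", "only" and "open" are said of these compounds alone.

Compound 1 `Cn1cc(-c2cn3c(Cc4ccc5ncccc5c4)cnc3cc2C(F)(F)F)cn1`: "not determined" (no result reported)
Compound 2 `N#Cc1ccc(-c2cc(F)c3ncc(Cc4ccc5ncccc5c4)n3c2)cn1`: 189 nM

Within the data shown here, in a functional assay on EBC-1 cells (Homo sapiens) for antiproliferative activity, with a stated time of 72 h (a lower number here means a stronger inhibitor, a higher number a weaker inhibitor), compound 2 gives 189 nM, the sole number so far, so it has no rank among other values. Compound 3 `CNC(=O)c1cccc(-c2cc(F)c3ncc(Cc4ccc5ncccc5c4)n3c2)c1` keeps the core of compound 2 and differs in one place: 3-(methylcarbamoyl)phenyl in place of 6-cyanopyridin-3-yl on an aromatic carbon. Among the measured compounds shown here, no measured step shows what a change at this position does. The expectation is therefore no shift beyond the scatter, with no firm direction, and the range stays wide. The expected change is a 1.3-fold lower number from compound 2 to compound 3 (0.10 log units; within the scatter). For compound 3 the estimated value is 150 nM, with an expected range of 40 nM to 600 nM.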

Compound 3, half-maximal inhibitory concentration: 400 nM
Estimate against measurement, compound 3: 2.7-fold (0.43 log units) below, within the range that was stated.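

In this assay the position now has its first measured step: 3-(methylcarbamoyl)phenyl in place of 6-cyanopyridin-3-yl gives a 2.1-fold higher number from compound 2 to compound 3 (0.33 log units; beyond the scatter) and so costs a modest but real amount of activity. The exchange changes the ring and its substituent together, and activity remains measurable with the carbon-only ring. No measurement at hand accounts for the step.

The pair does not separate the effect of the ring from that of the substituent. Also open, from the compounds shown here alone, is how a carboxylic acid or a primary amine on the phenyl ring would compare with the methylcarbamoyl group.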